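This account rests on a few compounds, and the source may have more. Where it says the series, first, only, none or still open, it means among the compounds named here.

Three compounds share one core and were followed in an in vivo ADME assay on the whole organism for pharmacokinetics, with Rattus norvegicus as the target; a higher number here means faster removal of the compound, a lower number slower removal. Compound 1 `O=C(O)CCCSCCN1C(=O)OC[C@@H]1/C=C/[C@@H](O)Cc1cccc(C(F)(F)F)c1` gives 67 mL/min/kg in this assay. Compound 2 `CCCc1cccc(C[C@H](O)/C=C/[C@H]2CSC(=O)N2CCSCCCC(=O)O)c1` gives 52 mL/min/kg in this assay. Compound 3 `Cc1cccc(C[C@H](O)/C=C/[C@H]2CCC(=S)N2CCSCCCC(=O)O)c1` gives 61 mL/min/kg in this assay. The number for compound 2 lies within the usual scatter of both other numbers, so on the present data the three compounds cannot be told apart in this assay.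

Compound 4 `O=C(O)CCCSCCN1C(=O)SC[C@@H]1/C=C/[C@@H](O)Cc1cccc(C(F)(F)F)c1` has not yet been measured. It differs from compound 2 in one place: trifluoromethyl in place of propyl on an aromatic carbon. Compound 1 already carries the same trifluoromethyl group on its six-membered aromatic ring of carbon only, and its number sits within the scatter of that of compound 2. For this reason no shift beyond the scatter is expected from the change. The expected step is a 1.1-fold higher number from compound 2 to compound 4 (0.05 log units; within the scatter), which is small and within the scatter. For compound 4 the expected clearance is 58 mL/min/kg, with a likely range from 35 mL/min/kg to 95 mL/min/kg.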

Compound 4, clearance: 51 mL/min/kg
Estimate against measurement, compound 4: 1.1-fold (0.06 log units) above; measured number inside the range.
By their numbers in this assay, from the lowest: compounds 4, 2, 3 and 1 (each within the scatter of the next).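

Across this position on the aromatic ring, with the rest of compound 2 and compound 4 the same, this assay gives the first direct one-place comparison, and trifluoromethyl in place of propyl makes no change that can be told from the scatter (a 1.0-fold lower number from compound 2 to compound 4 (0.01 log units; within the scatter)). The earlier compounds shown here differed from each other in more than one place, so they could not isolate this exchange. Nothing measured here explains why these two groups give such similar numbers.

The compounds shown leave open whether this position tolerates any group in this read-out or only these two, since an amine, a nitrile or a methoxy group at the same place would test very different atoms. They also leave open whether the same exchange behaves alike on the other cores shown.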